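Naphthalenoyl for benzoyl on a benzamide-type HDAC6 inhibitor

A few compounds are considered here, and "the series" means these few. Any claim that something is new, unique, unknown or untested is made for them only; others in the source may bear on it.

Compound 1, `Nc1ccccc1NC(=O)CCCCCN(CC(=O)NC1CCCCC1)C(=O)c1ccccc1`, gives > 10000 nM in an assay on Sf9 cells for inhibition of protein deacetylase HDAC6 (Homo sapiens), read by fluorescence, with a stated time of 90 min; on this read-out higher numbers stand for weaker inhibition and lower numbers for stronger inhibition.
Compound 2, `Nc1ccccc1NC(=O)c1ccc(CN(CC(=O)NCc2ccccc2)C(=O)c2cccnc2)cc1`, gives > 10000 nM in this assay.
Compound 3, `COc1ccc(CNC(=O)CN(CCCCCC(=O)Nc2ccccc2N)C(=O)c2cc(C)cc(C)c2)cc1`, gives > 10000 nM in this assay.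

All three measured compounds sit at the same point: the value for compound 1 is a limit of this assay and not a number, and compound 2 and compound 3 give the same limit, as the limit of > 10000 nM in this assay, at which 3 of the 3 values shown sit, states. Compound 1 therefore stands nowhere in an order; the numbers shown only say that none of the three reaches the measurable window.

Compound 4, `Nc1ccccc1NC(=O)CCCCCN(CC(=O)NC1CCCCC1)C(=O)c1cccc2ccccc12`, differs from compound 1 in one place: naphthalen-1-yl in place of phenyl on a carbonyl carbon. Within the data shown here, no step between measured compounds is given, so nothing in the data says what this change does. With compound 1 at a limit, any step from it cannot be sized from the data, and there is no ground for expecting a move beyond the usual scatter in either direction.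

Compound 4 is therefore expected to stay near the limit of compound 1, with a step that the limit leaves unreadable from compound 1 to compound 4, giving an estimated value of 12000 nM, between 4000 nM and 40000 nM, and most likely reported again only as a limit.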

Compound 4, half-maximal inhibitory concentration: > 10000 nM
Compound 4 gave a limit, no number (the forecaster's own chance of this, stated with the estimate: 70%); the middle value does not contradict the limit.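

No step can be read between compound 1 and compound 4, because both give the same limit and no number: the limit of > 10000 nM in this assay, at which 4 of the 4 values shown sit.

The compounds shown leave open what naphthalen-1-yl in place of phenyl does on a compound that gives a number in this assay.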